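The source may hold more compounds than are shown below. What is called first, only, known or untested is meant among the compounds shown, and "the series" means these compounds.

In a functional assay on HeLa cells (Homo sapiens) for inhibition, read by MTT assay, with a stated time of 48 h (a lower number here means a stronger inhibitor, a higher number a weaker inhibitor), three compounds sharing one core have been measured. Compound 1 (`CCOC(=O)C1=C(N/C=N/c2cccnc2Cl)Nc2[nH]nc(C)c2C1c1ccc(N(C)C)cc1`) gives 4630 nM, compound 2 (`CCOC(=O)C1=C(NN=C(C(C)=O)C(C)=O)Nc2[nH]nc(C)c2C1c1ccc(N(C)C)cc1`) gives 17000 nM, and compound 3 (`CCOC(=O)C(=NNC1=C(C(=O)OCC)C(c2ccc(N(C)C)cc2)c2c(C)n[nH]c2N1)C(=O)OCC`) gives 83800 nM. That last number is the highest of the three, making compound 3 the weakest inhibitor of the set. Compound 4 (`CCOC(=O)C1=C(N/N=C(/C(=O)Br)c2ccc(Cl)cc2)Nc2[nH]nc(C)c2C1c1ccc(N(C)C)cc1`) has not yet been measured. Its difference from compound 3 is a group of 12 heavy atoms (8 carbon, 1 nitrogen, 1 oxygen, 1 chlorine, 1 bromine; one six-membered aromatic ring of carbon only) in place of a group of 12 heavy atoms (7 carbon, 1 nitrogen, 4 oxygen; no ring), on an amine nitrogen, so the group that enters carries an aromatic ring and the group that leaves has none.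

For the measured compounds named here, three measured steps bear on this change. The largest is an 18-fold higher number from compound 1 to compound 3 (1.26 log units; beyond the scatter), where a group with no ring replaces one with an aromatic ring. The same kind of exchange gives a 3.7-fold higher number from compound 1 to compound 2 (0.56 log units; beyond the scatter), which is modest. Between two groups with no ring, a 4.9-fold higher number from compound 2 to compound 3 (0.69 log units; beyond the scatter) is also modest. Among the measured compounds only compound 1, at 4630 nM, has a ring in this group, so the expectation rests on a single compound, and its ring is not the one that enters here. A step to a lower number is therefore expected, of modest to large size and beyond the scatter. The estimated step is a 5.6-fold lower number from compound 3 to compound 4 (0.75 log units; beyond the scatter). For compound 4 the expected value is 15000 nM, with an estimated range from 4000 nM to 55000 nM.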

Compound 4, half-maximal inhibitory concentration: 49300 nM
For compound 4 the middle estimate is 3.3-fold (0.52 log units) below the measured one; measured number inside the range.
By their numbers in this assay, from the lowest: compound 1; then compound 2; then compounds 4 and 3 (each within the scatter of the next).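

In this assay, exchanging the ring-free group for one carrying a six-membered aromatic ring of carbon only gives a 1.7-fold lower number from compound 3 to compound 4 (0.23 log units; within the scatter), so on this amine nitrogen such a ring does not by itself set compound 4 apart from compound 3. For the compounds shown here, the same group gives a 2.9-fold higher number from compound 2 to compound 4 (0.46 log units; beyond the scatter) and, against the only other ring-bearing group, an 11-fold higher number from compound 1 to compound 4 (1.03 log units; beyond the scatter), so compound 4 goes against any reading that a ring in this group brings a low number, and the two ring-bearing compounds now lie far apart. Nothing measured alongside these compounds accounts for these differences.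

The group of compound 1 differs from that of compound 4 in several features at once, including its aromatic ring with a hetero atom, its ring chlorine and the chain that joins the ring to the amine nitrogen, and the compounds shown do not say which of these features goes with its lower number. They also leave open how this assay would read with a plain phenyl ring, or with an amide or a carboxylic acid in place of the carbonyl bromide of compound 4.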